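Trading the Amide Side Chain for a Bare Amino Group

A few compounds are considered here, and "the series" means these few. Any claim that something is new, unique, unknown or untested is made for them only; others in the source may bear on it.

Compound 3 `CNC(=O)COc1cc(=O)oc2cc(OCc3cccc(Cl)c3)ccc12` gives 33.9 nM in an assay on isolated protein (strain Sprague-Dawley) for inhibition of Amine oxidase [flavin-containing] B (Rattus norvegicus), read by spectrophotometry, with a stated time of 5 min; on this read-out higher numbers stand for weaker inhibition and lower numbers for stronger inhibition. It stands highest of the two single numbers, but compound 1 `CC(=O)COc1cc(=O)oc2cc(OCc3cccc(Cl)c3)ccc12` at 26.9 nM lies within the scatter of it, as the step of a 1.3-fold higher number from compound 1 to compound 3 (0.10 log units; within the scatter) shows. Compound 2 `NC(=O)COc1cc(=O)oc2cc(OCc3cccc(Cl)c3)ccc12` reads 3.1 nM; 3.31 nM (2 entries), with the repeat entries the several entries of compound 2 in this assay, 3.1 nM; 3.31 nM (2 entries) agreeing closely. Compound 4 `Nc1cc(=O)oc2cc(OCc3cccc(Cl)c3)ccc12` differs from compound 3 by amino in place of (methylcarbamoyl)methoxy on an aromatic carbon. For the measured compounds named here, no measured step removes this side chain: the only measured step alters just the carbonyl substituent and stays within the scatter, so it says little about the far larger change here. Compound 4 is therefore expected to come out near 40 nM, within 6 nM to 300 nM, a step of a 1.2-fold higher number from compound 3 to compound 4 (0.07 log units; within the scatter) whose direction remains uncertain.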

Compound 4, half-maximal inhibitory concentration: 47.9 nM
Compound 4: the middle estimate sits 1.2-fold (0.08 log units) below what was measured, and the stated range covers the measured number.
By their numbers in this assay, from the lowest: compounds 1, 3 and 4 (each within the scatter of the next).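

Cutting the side chain back to a lone amino group, on the aromatic carbon opposite the ring oxygen, gives a 1.4-fold higher number from compound 3 to compound 4 (0.15 log units; within the scatter) and a 1.8-fold higher number from compound 1 to compound 4 (0.25 log units; within the scatter) so neither (methylcarbamoyl)methoxy nor 2-oxopropoxy is needed to hold a number of this size. The printed values still set compound 2 at 3.1 nM; 3.31 nM (2 entries) and so lower than compound 4, which means that this one side chain stands apart from the bare amino group.

The compounds shown leave open how a hydroxyl group, a dimethylamino group or a longer amine chain on this carbon would read. Nothing given here points to a cause for this result.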